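Benzyl versus phenylpropyl thioethers on the shared nucleoside core

A few compounds are considered here, and "the series" means these few. Any claim that something is new, unique, unknown or untested is made for them only; others in the source may bear on it.

Measured so far:
compound 1 `O=[N+]([O-])c1ccc(O)c(CSc2ncnc3c2ncn3[C@@H]2O[C@H](CO)[C@@H](O)[C@H]2O)c1` — 33.1 nM
compound 2 `OC[C@H]1O[C@@H](n2cnc3c(SCCCc4ccccc4)ncnc32)[C@H](O)[C@@H]1O` — 1350 nM

In an assay on isolated protein for binding affinity to Equilibrative nucleoside transporter 1 (Homo sapiens) (on this read-out higher numbers stand for weaker inhibition and lower numbers for stronger inhibition), compound 1 gives 33.1 nM and compound 2 gives 1350 nM. Going by the values given here, compound 2 therefore stands at the higher of the two numbers, and the only measured step is a 41-fold higher number from compound 1 to compound 2 (1.61 log units; beyond the scatter), a large one.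

Compound 3 `Cc1cccc(CSc2ncnc3c2ncn3[C@@H]2O[C@H](CO)[C@@H](O)[C@H]2O)c1` is not yet measured. It differs from compound 2 by 3-methylphenyl in place of phenethyl on a saturated chain carbon bound to a sulfur; the same difference, cut one bond further out, reads 3-phenylpropyl to 3-methylbenzyl. Compound 3 thus resembles compound 1 in carrying the aromatic ring directly on the saturated chain carbon bound to the sulfur, but it lacks the hydroxy and nitro groups of the 2-hydroxy-5-nitrophenyl ring of compound 1 and carries a methyl instead. The step of a 41-fold higher number from compound 1 to compound 2 (1.61 log units; beyond the scatter) bears on this change only in part, since it alters both the chain and the ring substituents at once. A downward step is expected, but smaller than that measured step. The step expected is a 4.5-fold lower number from compound 2 to compound 3 (0.65 log units; beyond the scatter). Compound 3 is estimated at 300 nM with a range from 80 nM to 1200 nM.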

Compound 3, half-maximal inhibitory concentration: 12000 nM
The estimate for compound 3 lay 40-fold (1.60 log units) below the measured number; measured number above the stated range.
By their numbers in this assay, from the lowest: compound 1; then compound 2; then compound 3.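

In this assay the change from 3-phenylpropyl to 3-methylbenzyl gives an 8.9-fold higher number from compound 2 to compound 3 (0.95 log units; beyond the scatter) and so moves away from compound 1: placing the aromatic ring directly on the saturated chain carbon bound to a sulfur does not by itself bring the number down. With that arrangement shared, replacing 2-hydroxy-5-nitrophenyl with 3-methylphenyl gives a 360-fold higher number from compound 1 to compound 3 (2.56 log units; beyond the scatter) and this places the low number of compound 1 with its ring substituents, not with the benzyl thioether as such; compound 3 goes against any reading that a shorter chain alone lowers the number. Nothing on hand accounts for either step.

Still open, going by these compounds, is which of the hydroxy and nitro groups of compound 1 goes with its low number, the two appearing only together here, and how much of the step from compound 2 belongs to the chain and how much to the methyl, both of which change at once. An unsubstituted benzyl would separate the chain from the methyl, and a single hydroxy, nitro, amine or carboxylic acid on the benzyl ring would test the ring substituents one at a time.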